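A few compounds are considered here, and "the series" means these few. Any claim that something is new, unique, unknown or untested is made for them only; others in the source may bear on it.

Measured compounds in an ADME assay on BSC-1 cells (Cercopithecidae) for cytotoxicity; on this read-out lower numbers stand for stronger inhibition and higher numbers for weaker inhibition:

Compound 1 `CC(=O)OCCOCn1cc(C#N)c2c(N)ncnc21` gives > 100000 nM, which is a limit of this assay.
Compound 2 `N#Cc1cnc2n(COCCO)cnc(N)c1-2` gives > 100000 nM, which is a limit of this assay.
Compound 3 `NC(=O)c1cn(COCCO)c2ncnc(N)c12` gives > 100000 nM, which is a limit of this assay.

Compound 3 stands at the same limit as the other two measured compounds; no numbered value has been obtained for any of the three. Among the compounds with values here, the whole picture so far is summed up by the limit of > 100000 nM in this assay, at which 3 of the 3 values shown sit, so there is no measured step in this assay from which a direction could be read.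

Compound 4 `NC(=S)c1cn(COCCO)c2ncnc(N)c12` is the next member. The change from compound 3 is a group of 3 heavy atoms (1 carbon, 1 nitrogen, 1 sulfur; no ring) in place of a group of 3 heavy atoms (1 carbon, 1 nitrogen, 1 oxygen; no ring), on an aromatic carbon. Nothing measured here shows how such a swap moves this read-out.

Given that every measured compound sits at the limit, compound 4 is expected to remain at or near it, with a step of a number no higher from compound 3 to compound 4 (the limit leaves the size open) of no size beyond the scatter. The estimate for compound 4 is 100000 nM, with a range from 30000 nM to 300000 nM.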

Compound 4, half-maximal inhibitory concentration: > 100000 nM
Compound 4 gave a limit, no number (the forecaster's own chance of this, stated with the estimate: 80%); the middle value lies on the limit itself.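

In this assay compound 4 gives > 100000 nM, which is a limit and not a number. Within the data shown here, compound 3 also stands at a limit, so no step from compound 3 to compound 4 can be read. How the loss of carbamoyl moves this assay stays open, as does any numbered value for these compounds, since the data offer only this: the limit of > 100000 nM in this assay, at which 4 of the 4 values shown sit.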